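Replacing a Methoxy Group with a Dichlorophenyl Ring

This account rests on a few compounds, and the source may have more. Where it says the series, first, only, none or still open, it means among the compounds named here.

Compound 1 `C=C[C@@](C)(/C=C/c1ccc(OC)cc1)CCC=C(C)C` — > 36600 nM
Compound 2 `C=C[C@@](C)(/C=C/c1ccc(O)cc1)CC/C=C(C)/C=C/C(=O)OCC` — > 36600 nM
Compound 3 `C=C[C@@](C)(/C=C/c1ccc(Nc2ccc(OC)c(OC)c2)cc1)CCC=C(C)C` — > 36600 nM

Of the compounds shown here, three have so far been tested in a functional assay on SEM cells (Homo sapiens) for cytotoxicity, with a stated time of 72 h; a higher number here means that more compound is needed for the effect, a lower number that less compound is needed. Compound 1 reaches only the ceiling of this assay, and its value of > 36600 nM is a limit rather than a number. Compound 2 likewise gives only a limit, > 36600 nM. Compound 3 also gives only a limit, > 36600 nM. All three sit at the limit of > 36600 nM in this assay, at which 3 of the 3 values shown sit. Compound 1 therefore stands exactly where every other measured compound stands: at the top of what this assay can report, with nothing to separate it from compounds 2 and 3.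

Compound 4 `C=C[C@@](C)(/C=C/c1ccc(-c2ccc(Cl)c(Cl)c2)cc1)CCC=C(C)C` has not yet been measured. It differs from compound 1 in a single place: 3,4-dichlorophenyl in place of methoxy on an aromatic carbon. Among the compounds with values here, no step between two measured compounds exists in this set, since all three values are limits, so there is no measured direction to lean on. Compound 4 is expected to give a result in this assay of about 30000 nM, with a plausible range from 8000 nM to 60000 nM. The step this estimate implies, an at least 1.2-fold lower number from compound 1 to compound 4 (0.08 log units; that floor lies within the scatter), is expected to stay within the usual scatter, with a real chance that compound 4 also returns only a limit.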

Compound 4, half-maximal effective concentration: > 36600 nM
Compound 4 gave a limit, no number (the forecaster's own chance of this, stated with the estimate: 55%); middle value at least 1.2-fold (0.08 log units) away from the limit.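

In this assay compound 4 gives > 36600 nM, which is a limit and not a number. Compound 1 also gives only a limit, so no step can be read between compound 1 and compound 4: the limit of > 36600 nM in this assay, at which 4 of the 4 values shown sit. The compounds shown leave open whether 3,4-dichlorophenyl in place of methoxy makes any difference in this assay.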